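Ring Size Change on the Aminomethyl Side Chain

The compounds below may be only part of what the source reports. "The series", "measured", "known", "first", "only" and "open" are said of these compounds alone.

In an assay for inhibition of Tryptophan 2,3-dioxygenase (Homo sapiens), with stated times of 10 min and 60 min (on this read-out higher numbers stand for weaker inhibition and lower numbers for stronger inhibition), compound 1 `FC(F)(F)c1cc(NC[C@H]2CCCN2)c2cn[nH]c2c1` gives 6090 nM and compound 2 `Oc1ccc(CNc2cc(C(F)(F)F)cc3[nH]ncc23)c(Cl)c1` gives 2680 nM. For compound 3 `FC(F)(F)c1cc(NCC2CNC2)c2cn[nH]c2c1` this assay reports only a limit, > 100000 nM. Going by the values given here, compound 3 therefore stands at the limit (the limit of > 100000 nM in this assay, at which 1 of the 3 values shown sits), and the single step leading onto it, an at least 16-fold higher number from compound 1 to compound 3 (1.21 log units; beyond the scatter), is large. Compound 4 `FC(F)(F)c1cc(NC[C@H]2CCCCN2)c2cn[nH]c2c1` carries piperidin-2-yl in place of azetidin-3-yl on a saturated chain carbon bound to a nitrogen on an aromatic ring. Since piperidin-2-yl is the ring homolog of the pyrrolidin-2-yl of compound 1, whose value is 6090 nM, compound 4 is expected to move back toward that region, with an expected step of an at least 8.3-fold lower number from compound 3 to compound 4 (0.92 log units; beyond the scatter) downward in this assay. Compound 4 is estimated at 12000 nM, within a range from 3000 nM to 50000 nM.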

Compound 4, half-maximal inhibitory concentration: 460 nM
The estimate for compound 4 lay 26-fold (1.42 log units) above the measured number, and the stated range ends above it.
By their numbers in this assay, from the lowest: compound 4; then compound 2; then compound 1. At a limit, above all of these: compound 3.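

Among the rings carried on this saturated chain carbon, the piperidin-2-yl of compound 4 shows that a larger ring is tolerated and in fact favoured over the pyrrolidin-2-yl, with a 13-fold lower number from compound 1 to compound 4 (1.12 log units; beyond the scatter). The other step, an at least 210-fold lower number from compound 3 to compound 4 (2.33 log units; beyond the scatter), goes well beyond restoring the level of compound 1. Compound 3 gives only a limit, so that step is a bound and not an exact size: the limit of > 100000 nM in this assay, at which 1 of the 4 values shown sits.

As far as these compounds go, whether the gain continues with a larger azepan-2-yl ring remains open. So does whether the ring nitrogen is needed, as a cyclohexyl group would test.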